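Methyl for chloro on two different rings of a benzimidazole series

The source may report more compounds than this note shows. Statements on the series, on what has been measured and on what is new or still open speak of the compounds shown alone.

Of the compounds shown here, three have been tested in an ADME assay on Vero cells (Chlorocebus sabaeus) for cytotoxicity, read by luminescence, with a stated time of 2 days; on this read-out lower numbers stand for higher toxicity in this test and higher numbers for lower toxicity in this test. Compound 1 `CCc1nc2ccccc2n1CCCCOc1ccc(Cl)cc1Cl` gives 23 uM. Compound 2 `CCc1nc2ccccc2n1CCCCOc1ccc(Cl)cc1C` gives 20 uM. Compound 3 `CCc1nc2ccc(Cl)cc2n1CCCCOc1ccccc1` gives 25 uM. Between compound 1 and compound 2 the difference is methyl in place of chloro on an aromatic carbon, and that step is a 1.2-fold lower number from compound 1 to compound 2 (0.06 log units; within the scatter). The values of compound 3 and compound 1 lie within the scatter of each other, as do those of compound 3 and compound 2; the difference between the two cores of compound 1 and compound 3 is not broken down here.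

Compound 4 `CCc1nc2ccc(C)cc2n1CCCCOc1ccccc1` has not yet been measured in this assay. It differs from compound 3 by methyl in place of chloro on an aromatic carbon. This is the same kind of change as from compound 1 to compound 2, but the place differs: there it was on a ring that was ortho to a large group and meta to a chloro group, here it is on a ring that is part of a fused or bridged system of two rings, meta and para to a fused ring.

Because the earlier step was a 1.2-fold lower number from compound 1 to compound 2 (0.06 log units; within the scatter), the expected step from compound 3 to compound 4 is a 1.1-fold lower number from compound 3 to compound 4 (0.06 log units; within the scatter). The estimate for compound 4 in this assay is 22 uM, expected to fall between 12 uM and 40 uM.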

Compound 4, half-maximal toxic concentration: 18 uM
Estimate against measurement, compound 4: 1.2-fold (0.09 log units) above, within the range that was stated.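

On the ring that is part of a fused system of two rings, methyl in place of chloro gives in this assay a 1.4-fold lower number from compound 3 to compound 4 (0.14 log units; within the scatter), so the change does not move the number beyond the scatter on this core. Set beside the step on the other ring, the change carries from one core to the other with no difference that can be told from the scatter: the same change on two cores in this assay, a 1.2-fold lower number (0.06 log units; within the scatter) from compound 1 to compound 2 and a 1.4-fold lower number (0.14 log units; within the scatter) from compound 3 to compound 4, 1.2-fold (0.08 log units) apart, within the scatter of two such steps This shows only that the change stayed small on these two cores, and with both steps inside the scatter it does not show that the change has any effect of its own on this read-out, nor does it make a rule for the whole series.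

The compounds shown carry only chloro or methyl at the places that change, so it stays open how an amine or a carboxylic acid there would read in this assay. From the compounds shown here alone, it also stays open whether the step would keep its size on a core with a longer chain.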